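Cyclopentyl on the core nitrogen: expectation for compound 4

The source may hold more compounds than are shown below. What is called first, only, known or untested is meant among the compounds shown, and "the series" means these compounds.

Measured compounds:
Compound 1 `CCC(C)n1cnc2c(NCc3ccc(C(=O)Nc4ccccc4N)cc3)nc(Cl)nc21`: 75.1%
Compound 2 `CCCCn1cnc2c(NCc3ccc(C(=O)Nc4ccccc4N)cc3)nc(Cl)nc21`: 40.9%
Compound 3 `CC(C)n1cnc2c(NCc3ccc(C(=O)Nc4ccccc4N)cc3)nc(Cl)nc21`: 76%

In a functional assay on HCT-116 cells (Homo sapiens) for antiproliferative activity, read by CCK-8 assay, with a stated time of 72 h, tested at 8 uM (a higher number here means a stronger effect of the compound at the concentration tested, a lower number a weaker effect), compound 3 gives the highest of the three numbers, yet its gap to compound 1 is within the scatter, so the two cannot be ordered. Compound 4 `Nc1ccccc1NC(=O)c1ccc(CNc2nc(Cl)nc3c2ncn3C2CCCC2)cc1` differs from compound 3 by cyclopentyl in place of isopropyl on an aromatic nitrogen.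

Among the compounds with values here, two measured steps bear on this position. The change a number 35.1 percentage points higher from compound 2 to compound 3 (beyond the scatter) was large, and a number 0.9 percentage points higher from compound 1 to compound 3 (within the scatter) was within the scatter, while a number 34.2 percentage points lower from compound 1 to compound 2 (beyond the scatter) was a large drop. The numbers therefore cluster at two levels, with compound 2 apart. Within the data shown here, no measured step tests a ring at this nitrogen, so the direction remains open.

Compound 4 is expected to stay near compound 3, with an estimated step of a number 8 percentage points lower from compound 3 to compound 4 (within the scatter), giving an estimate of 68% within 45% to 85%.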

Compound 4, a percentage reported as inhibition, at one concentration (the size of the read-out at that concentration, not a potency): 80.6%
Estimate against measurement, compound 4: 12.6 percentage points below, within the range that was stated.
By their numbers in this assay, from the lowest: compound 2; then compounds 1, 3 and 4 (each within the scatter of the next).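

In this assay a ring at this nitrogen stays level with the branched groups, as cyclopentyl in place of isopropyl (a number 4.6 percentage points higher from compound 3 to compound 4 (within the scatter)) and in place of sec-butyl (a number 5.5 percentage points higher from compound 1 to compound 4 (within the scatter)) both remain within the scatter. Against the straight chain the ring stands clearly apart (a number 39.7 percentage points higher from compound 2 to compound 4 (beyond the scatter)), leaving compound 2 with its butyl as the only one separated among the four. Nothing available explains this level or the gap to butyl.

From the compounds shown here alone, whether cyclopropyl or cyclohexyl at this nitrogen would hold the same level remains open. So does the effect of an amine or a hydroxyl on the cyclopentyl ring.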